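Trading Dichlorophenyl for Ethylphenyl: What Half-Life to Expect

A few compounds are considered here, and "the series" means these few. Any claim that something is new, unique, unknown or untested is made for them only; others in the source may bear on it.

Compound 1 `Cc1oc(-c2c(Cl)cccc2Cl)nc1CN1CCC(C(=O)NCCCN2C[C@H](C)C[C@H](C)C2)CC1` is one of two compounds with a result in an ADME assay on microsomes from liver (Rattus norvegicus) for metabolic stability, read by LC-MS, using NADPH, at 37 degrees C; on this read-out lower numbers stand for a shorter-lived compound and higher numbers for a longer-lived compound. In this assay compound 1 gives 0.0483 h, the only plain number shown, so it stands alone rather than within a series. Compound 2 `Cc1ccccc1-c1nc(CN2CCC(C(=O)N3CCN(C4CCN(C)CC4)CC3)CC2)c(C)o1` is the other measured compound. In this assay compound 2 gives > 0.5 h, a limit of the assay rather than a number, namely (the limit of > 0.5 h in this assay, at which 1 of the 2 values shown sits). Compound 2 differs from compound 1 in more than one part, so no single step can be read between them.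

Compound 3 `CCc1ccccc1-c1nc(CN2CCC(C(=O)NCCCN3C[C@H](C)C[C@H](C)C3)CC2)c(C)o1` has not been measured. It differs from compound 1 at one place: 2-ethylphenyl in place of 2,6-dichlorophenyl on an aromatic carbon. Going by the values given here, with no single-change step to lean on, the expected step in this assay is a small rise, a 1.7-fold higher number from compound 1 to compound 3 (0.22 log units; within the scatter), which may stay within the usual scatter. Compound 3 is estimated to give 0.08 h, within a range from 0.03 h to 0.25 h.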

Compound 3, half-life: 0.283 h
Estimate against measurement, compound 3: 3.5-fold (0.55 log units) below; the measured number lies above the stated range.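

Measured in this assay, swapping the aryl group gives a 5.9-fold higher number from compound 1 to compound 3 (0.77 log units; beyond the scatter), and that step lies beyond the usual scatter. Going by these compounds alone, this is the first clean reading at this position, since compound 2 differs from compound 1 in more than one part: here the rest of the molecule stays the same, so the change in half-life goes with this one swap, and the group on this aromatic carbon clearly counts. The two groups match in heavy-atom count and in their carbon-only aromatic ring, yet nothing shown explains why the number moves.

A plain phenyl or a 2-chlorophenyl in this place would help to tell whether the rise goes with losing the chlorines or with gaining the ethyl. Going by these compounds, whether the same step holds with a different side chain on the shared core also remains open.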